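The source may report more compounds than this note shows. Statements on the series, on what has been measured and on what is new or still open speak of the compounds shown alone.

Measured in a functional assay on MOLT-4 cells (Homo sapiens) for inhibition, read by sulforhodamine B assay, with a stated time of 48 h, tested at 0.1 uM; on this read-out higher numbers stand for a weaker effect at the one concentration tested and lower numbers for a stronger effect:
compound 1 `O=C(Nc1cccc(-n2cc(-c3ccncc3)c(-c3cc(O)cc(Cl)c3)n2)c1)Nc1ccc(Cl)c(C(F)(F)F)c1` gives 92%
compound 2 `COc1cc(Cl)cc(-c2nn(-c3cccc(NC(=O)Nc4ccc(Cl)c(C(F)(F)F)c4)c3)cc2-c2ccncc2)c1` gives 57%
compound 3 `COc1cc(Cl)cc(-c2nn(-c3cccc(NC(=O)Nc4cc(C(F)(F)F)cc(C(F)(F)F)c4)c3)cc2-c2ccncc2)c1` gives 87%

Compound 2 stands lowest of the three numbers in this assay; its gap to compound 3 and its larger gap to compound 1 are both beyond the scatter, so compound 2 shows the strongest effect of the three at this concentration.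

Compound 4 `COc1cc(Cl)cc(-c2nn(-c3cccc(NC(=O)c4cccc(C(F)(F)F)c4)c3)cc2-c2ccncc2)c1` differs from compound 2 in one place: 3-(trifluoromethyl)phenyl in place of (4-chloro-3-(trifluoromethyl)phenyl)amino on a carbonyl carbon

Among the compounds with values here, the single step measured in one place, a number 35 percentage points lower from compound 1 to compound 2 (beyond the scatter), concerns the oxygen on the aromatic ring and does not touch the urea end, so it gives no direct guide here. Compound 2 and compound 3 differ only in the aryl group carried by the urea, and compound 3 shows the markedly higher number; this end of the molecule is therefore not indifferent to change. Nothing measured removes the amino part of the urea or the chlorine. Given the values of compound 2 and compound 3 at this end, the step of a number 23 percentage points higher from compound 2 to compound 4 (beyond the scatter) is expected to run toward a higher number, beyond the scatter. Compound 4 is estimated at 80%, within 58% to 100%.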

Compound 4, a percentage reported as activity, at one concentration (the size of the read-out at that concentration, not a potency): 95%
For compound 4 the middle estimate is 15 percentage points below the measured one; low and high end bracket the measured number.
By their numbers in this assay, from the lowest: compound 2; then compounds 3, 1 and 4 (each within the scatter of the next).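

In this assay the change at the carbonyl carbon gives a number 38 percentage points higher from compound 2 to compound 4 (beyond the scatter), so the effect seen with the urea in compound 2 does not survive replacing (4-chloro-3-(trifluoromethyl)phenyl)amino with 3-(trifluoromethyl)phenyl. Within the data shown here, earlier variation at this end kept the urea and changed only the aryl group, whereas this step removes the amino nitrogen, with its hydrogen-bond donor, and the chlorine together, and the single step cannot separate the two. No supporting measurement accounts for the size of this step.

Still open, as far as these compounds go, is whether a urea lacking only the chlorine, or an amide keeping it, would stay close to compound 2 or to compound 4. Also open, from the compounds shown here alone, is how a sulfonamide or a carbamate in place of the urea would read out at this end.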